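Oxazole amide series: aryl swap and microsomal half-life

A few compounds are considered here, and "the series" means these few. Any claim that something is new, unique, unknown or untested is made for them only; others in the source may bear on it.

The series shares one core with an aryl group on the five-membered ring. The measured members are compound 1 `Cc1ccccc1-c1nc(CN2CCC(C(=O)NCCCN3[C@H](C)CCC[C@@H]3C)CC2)c(C)o1`, compound 2 `Cc1oc(-c2c(Br)cccc2Br)nc1CN1CCC(C(=O)NCCCN2C[C@H](C)C[C@H](C)C2)CC1` and compound 3 `Cc1ccccc1-c1nc(CN2CCC(C(=O)N3CCN(C4CCN(C)CC4)CC3)CC2)c(C)o1`, all read in an ADME assay on microsomes from liver (Rattus norvegicus) for metabolic stability, read by LC-MS, using NADPH, at 37 degrees C; a higher number here means that the compound lasts longer, a lower number that the compound disappears faster.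

Among the compounds with values here, compound 2 gives 0.035 h in this assay, the only plain number among the three. Compound 1 returns only a limit, > 0.5 h. Compound 3 likewise stops at a limit, > 0.5 h. Compound 2 therefore stands alone with a read half-life, while the other two sit at the limit of > 0.5 h in this assay, at which 2 of the 3 values shown sit. Within the data shown here, no pair of measured compounds differs in one place only, so no measured step is available.

Compound 4 `Cc1cccc(C)c1-c1nc(CN2CCC(C(=O)NCCCN3C[C@H](C)C[C@H](C)C3)CC2)c(C)o1` is the next member. It differs from compound 2 by 2,6-dimethylphenyl in place of 2,6-dibromophenyl on an aromatic carbon. Neither compound 1 nor compound 3 carries a 2,6-dibromophenyl, and both reach the limit in this assay. On that basis the step from compound 2 to compound 4 is expected to be upward and beyond the scatter, as an 8.6-fold higher number from compound 2 to compound 4 (0.93 log units; beyond the scatter). The expectation rests on compound 1, which gives only the limit > 0.5 h. Compound 4 is estimated at 0.3 h, within 0.08 h to 0.6 h, with a real chance that this assay again reports only a limit.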

Compound 4, half-life: 0.0517 h
Compound 4: the middle estimate sits 5.8-fold (0.76 log units) above what was measured; the measured number lies below the stated range.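

In this assay, within the data shown here, the only measured one-place step concerns an aromatic carbon of the five-membered aromatic ring, where 2,6-dimethylphenyl stands in place of 2,6-dibromophenyl (a 1.5-fold higher number from compound 2 to compound 4 (0.17 log units; within the scatter)). With the rest of compound 2 held constant, this read-out does not separate the two aryl groups, so the two bromine atoms alone do not mark compound 2 out from compound 4. Compound 1 and compound 3 remain the members that give only a limit, and each differs from compound 4 in more than one place: the limit of > 0.5 h in this assay, at which 2 of the 4 values shown sit.

The compounds shown leave open whether the aryl group or the amide side separates the limit values from the two read half-lives, as no measured step isolates either part. Also open, on these data alone, is how a phenyl bearing a nitrile or a carboxylic acid would read at this position in this assay, with the rest of compound 4 unchanged.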